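The source may hold more compounds than are shown below. What is called first, only, known or untested is meant among the compounds shown, and "the series" means these compounds.

Values in a physicochemical assay for lipophilicity, read by HPLC (a higher number here means a more lipophilic compound, a lower number a more polar compound), for the measured compounds
- compound 1 `CCCn1cc(C(=O)NCc2ccccc2)c(=O)c2cc(F)c(N3CCC(C(N)=O)CC3)cc21` gives 2.4
- compound 2 `NC(=O)C1CCN(c2cc3c(cc2F)c(=O)c(C(=O)NCc2ccccc2)cn3C2CC2)CC1` gives 2.4
- compound 3 `CCCCn1cc(C(=O)NCc2ccc(OC)cc2)c(=O)c2cc(F)c(N3CCC(C(N)=O)CC3)cc21` gives 2.4

Compound 3 stands level with compound 1 and compound 2 on these numbers. The next compound, compound 4 `CCCCn1cc(C(=O)NCc2ccco2)c(=O)c2cc(F)c(N3CCC(C(N)=O)CC3)cc21`, differs from it in one place: furan-2-yl in place of 4-methoxyphenyl on a saturated chain carbon bound to an amide-type nitrogen. For the measured compounds named here, the only measured single-place step, no change at the digits printed from compound 1 to compound 2 (within the scatter), is a different change, so it offers little guidance on size here. Going by the values given here, no measured step covers this swap, and the expectation rests on the smaller entering group alone. A modest downward move in this assay is therefore expected, a number 0.50 log units lower from compound 3 to compound 4 (beyond the scatter), though with real uncertainty. For compound 4 the estimate is 1.9, within a range from 1.5 to 2.3.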

Compound 4, partition coefficient: 2.4
For compound 4 the middle estimate is 0.50 log units below the measured one, outside the stated range (above it).
By their numbers in this assay, from the lowest: compounds 1, 2, 3 and 4 (each within the scatter of the next).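

In this assay, for the compounds shown here, furan-2-yl in place of 4-methoxyphenyl on a saturated chain carbon bound to an amide-type nitrogen gives no change at the digits printed from compound 3 to compound 4 (within the scatter), the first reading of a change at this position. For this pair, a smaller group with a five-membered aromatic ring leaves the number level with that of the larger group with a six-membered ring. Nothing available explains this result. This is a single pair, so it sets no rule for the position. From the compounds shown here alone, what an amine or a carboxylic acid in place of furan-2-yl would do remains open.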